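Second chloro group on compound 2: cytotoxicity notes

A few compounds are considered here, and "the series" means these few. Any claim that something is new, unique, unknown or untested is made for them only; others in the source may bear on it.

Compound 1 (`OCc1cn(Cc2cccc(Cl)c2)c2ccccc12`) gives > 31600 nM in an ADME assay on T29 cells (Homo sapiens) for cytotoxicity, read by sulforhodamine B assay, with a stated time of 3 days (on this read-out lower numbers stand for stronger inhibition and higher numbers for weaker inhibition), as a limit of the assay, not a number. Compound 2 (`OCc1cn(Cc2ccc(Cl)cc2)c2ccccc12`) likewise gives > 31600 nM as a limit and no number. The series therefore stands at the limit of > 31600 nM in this assay, at which 2 of the 2 values shown sit, and no more can be read from it. Compound 3 (`OCc1cn(Cc2ccc(Cl)c(Cl)c2)c2ccccc12`) carries chloro in place of hydrogen on an aromatic carbon, ortho to a chloro group and meta to a large group. Going by the values given here, no measured step yet shows what such a change does in this assay, so no step beyond the scatter is expected, in either direction. The expected change is a step that the limit leaves unreadable from compound 2 to compound 3 and rests only on the limit of compound 2. The estimated value for compound 3 is 35000 nM (expected range 15000 nM to 80000 nM), and another report as a limit is likely.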

Compound 3, half-maximal inhibitory concentration: > 31600 nM
Compound 3 ended at the assay's limit (the forecaster's own chance of this, stated with the estimate: 75%); the middle value lies beyond the limit too.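

The steps from compound 1 and from compound 2 to compound 3 cannot be read in this assay, and the series stays at a limit, not a number: the limit of > 31600 nM in this assay, at which 3 of the 3 values shown sit.

The compounds shown leave open whether any change on the shared core would give a readable value in this assay.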